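The source may report more compounds than this note shows. Statements on the series, on what has been measured and on what is new or still open speak of the compounds shown alone.

Measured so far in an ADME assay on L6 cells (Rattus norvegicus) for cytotoxicity, with a stated time of 72 h; on this read-out higher numbers stand for weaker inhibition and lower numbers for stronger inhibition
- compound 1 `CN(C)C12CC(OC(=O)CN3CCCC3)C(C(c3ccccc3)C1)C(c1ccccc1)C2` gives 32700 nM
- compound 2 `CC(C)(C)C(=O)OC1CC2(N3CCCC3)CC(c3ccccc3)C1C(c1ccccc1)C2` gives 7620 nM
- compound 3 `O=C(CN1CCCCC1)OC1CC2(N3CCCC3)CC(c3ccccc3)C1C(c1ccccc1)C2` gives 14200 nM

Compound 1 at 32700 nM has the highest number of the three. Compound 3 at 14200 nM lies nearest to it and compound 2 at 7620 nM furthest, both gaps beyond the scatter.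

Compound 4 `CN(C)C12CC(O)C(C(c3ccccc3)C1)C(c1ccccc1)C2` is not yet measured. The change from compound 1 is hydrogen in place of ((pyrrolidin-1-yl)methyl)carbonyl on an oxygen on a saturated carbon and the rest of the structure stays the same.

Among the measured compounds shown here, the only measured step is a 1.9-fold higher number from compound 2 to compound 3 (0.27 log units; within the scatter) and it stays within the scatter. For the measured compounds named here, that step exchanges one group on a carbonyl carbon for another, and no measured pair shows the removal of the ((pyrrolidin-1-yl)methyl)carbonyl. The guidance is therefore weak, and no step beyond the scatter is expected in this assay for this change.

The estimated step is a 1.2-fold higher number from compound 1 to compound 4 (0.09 log units; within the scatter) as an expectation only. For compound 4 the expected value is 40000 nM with 14000 nM to 110000 nM as the estimated range.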

Compound 4, half-maximal inhibitory concentration: 133000 nM
The estimate for compound 4 lay 3.3-fold (0.52 log units) below the measured number, and the stated range ends below it.
By their numbers in this assay, from the lowest: compounds 2 and 3 (each within the scatter of the next); then compound 1; then compound 4.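

In this assay, among the compounds shown here, replacing the (((pyrrolidin-1-yl)methyl)carbonyl)oxy group with hydroxy gives a 4.1-fold higher number from compound 1 to compound 4 (0.61 log units; beyond the scatter), the first single-place change to go beyond the scatter. The earlier step, a 1.9-fold higher number from compound 2 to compound 3 (0.27 log units; within the scatter), exchanged one group on a carbonyl carbon for another and stayed within the scatter, whereas this result shows that removing the whole group from the oxygen does register on this read-out, with weaker inhibition for the free hydroxy compound. No supporting data bear on why this step occurs.

From the compounds shown here alone, it remains open whether the step follows from the ester carbonyl itself or from the pyrrolidine ring, which a simple acetyl group on the same oxygen would help separate. Going by these compounds, it is also open whether hydroxy in place of the ester gives a similar step on the core of compound 2.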